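Aryl swap on the ring nitrogen, all at the limit

The source may report more compounds than this note shows. Statements on the series, on what has been measured and on what is new or still open speak of the compounds shown alone.

The series shares one core and differs only in the aryl group on an aromatic nitrogen of a five-membered aromatic ring with 3 nitrogen. Compound 1 `Cc1ccccc1-n1nncc1CN1C(=O)C2(C(C#N)=C(N)Oc3c(N)cc4nc5ccccc5nc4c32)c2ccccc21` carries 2-methylphenyl there; in an ADME assay on HUVEC cells (Homo sapiens) for antiproliferative activity, read by MTT assay, with a stated time of 48 h (a lower number here means a stronger inhibitor, a higher number a weaker inhibitor), compound 1 returns only the assay limit, > 50000 nM. Compound 2 `CCc1cccc(CC)c1-n1nncc1CN1C(=O)C2(C(C#N)=C(N)Oc3c(N)cc4nc5ccccc5nc4c32)c2ccccc21` carries 2,6-diethylphenyl, and in this assay compound 2 likewise stays at the limit, > 50000 nM. Compound 3 `N#CC1=C(N)Oc2c(N)cc3nc4ccccc4nc3c2C12C(=O)N(Cc1cnnn1-c1ccc(Cl)cc1Cl)c1ccccc12` carries 2,4-dichlorophenyl; in this assay compound 3 also gives only a limit, > 50000 nM. Compound 3 therefore stands exactly where every measured member stands, at the limit of > 50000 nM in this assay, at which 3 of the 3 values shown sit, and no order among the three can be read. The step that the two limits leave unreadable from compound 1 to compound 2 is unreadable, as are a step that the two limits leave unreadable from compound 1 to compound 3 and a step that the two limits leave unreadable from compound 2 to compound 3.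

Compound 4 `Cc1ccc(-n2nncc2CN2C(=O)C3(C(C#N)=C(N)Oc4c(N)cc5nc6ccccc6nc5c43)c3ccccc32)cc1Cl` takes the next such step: 3-chloro-4-methylphenyl in place of 2,4-dichlorophenyl on an aromatic nitrogen. Within the data shown here, the steps that bear on it, a step that the two limits leave unreadable from compound 1 to compound 3 and a step that the two limits leave unreadable from compound 2 to compound 3, each exchange one aryl for another on the same nitrogen, and each is unreadable because the limit of > 50000 nM in this assay, at which 3 of the 3 values shown sit, holds both ends. Among the measured compounds shown here, no size of step can thus be derived; the expected step is a step that the limit leaves unreadable from compound 3 to compound 4, with no direction beyond the scatter. Compound 4 is expected at 60000 nM, in the range 20000 nM to 200000 nM, most probably reported again only as a limit.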

Compound 4, half-maximal inhibitory concentration: > 50000 nM
Compound 4 ended at the assay's limit; the forecaster's own chance of this, stated with the estimate: 85%; the middle value lies beyond the limit too.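

In this assay compound 4 gives only a limit, > 50000 nM. No step between compound 4 and compound 1, compound 2 or compound 3 can be read, because all four compounds sit at the same limit: the limit of > 50000 nM in this assay, at which 4 of the 4 values shown sit.

The compounds shown leave open whether any aryl group on this nitrogen gives a measurable value in this assay.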